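Aryl substitution in a sulfonamide piperidine series

The compounds below may be only part of what the source reports. "The series", "measured", "known", "first", "only" and "open" are said of these compounds alone.

Measured compounds:
compound 1 `COc1ccc(S(=O)(=O)NCCN2CCC(CCC(=O)c3cc(Cl)c(N)cc3OC)CC2)cc1Br` — "not active" (no number reported)
compound 2 `COc1ccc(S(=O)(=O)NCCN2CCC(CCC(=O)c3cc(Cl)c(N)cc3OC)CC2)cc1` — 36%

In an assay on HEK293 cells for displacement of a labelled ligand from 5-hydroxytryptamine receptor 6 (Homo sapiens), with a stated time of 60 min, tested at 0.01 uM, in the presence of a further agent that is not named here (a higher number here means a stronger effect of the compound at the concentration tested, a lower number a weaker effect), compound 1 is reported as "not active" (no number reported), with no number attached. In this assay compound 2 gives 36%, the only numerical result in the set so far; it stands on its own, with one further entry lacking a number. For the measured compounds named here, no pair of measured compounds differing in one place is available, so no measured step can be quoted.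

Compound 3 `COc1cc(N)c(Cl)cc1C(=O)CCC1CCN(CCNS(=O)(=O)c2ccc(OC)c(N3CCN(C)CC3)c2)CC1` is the next compound to be measured. It differs from compound 2 by 4-methylpiperazin-1-yl in place of hydrogen on an aromatic carbon, on an aromatic carbon ortho to a methoxy group and meta to a large group. Going by the values given here, with no comparable step among the measured compounds, the expectation for the step from compound 2 to compound 3 rests on the single value of compound 2 only, and a modest change in this assay is expected, a number 9 percentage points higher from compound 2 to compound 3 (within the scatter), about at the edge of the usual scatter and slightly upward. Compound 3 is therefore estimated at 45%, with a range from 15% to 75%.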

Compound 3, a percentage reported as inhibition, at one concentration (the size of the read-out at that concentration, not a potency): 4%
The estimate for compound 3 lay 41 percentage points above the measured number, outside the stated range (below it).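

In this assay, for the compounds shown here, the first measured step at this position is large: a number 32 percentage points lower from compound 2 to compound 3 (beyond the scatter), with 4-methylpiperazin-1-yl in place of hydrogen on the aromatic carbon ortho to a methoxy group. Before this, the only other substituent at this carbon was the bromine of compound 1, reported as "not active" (no number reported), which gave no number to set against compound 2. Substitution here now has a measured cost, and both substituted compounds read poorly beside the unsubstituted compound 2, although only one of the two changes has a number. Nothing measured explains the loss.

On these data alone, it remains open whether a methyl group, a fluorine atom or morpholin-4-yl on this carbon would keep the reading of compound 2. Readings at a single concentration also leave the potencies of all three compounds undefined.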